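Furan in place of pyridine on the amide carbonyl

The source may report more compounds than this note shows. Statements on the series, on what has been measured and on what is new or still open speak of the compounds shown alone.

Two members of this series have been measured in a functional assay on SK-BR-3 cells (Homo sapiens) for antiproliferative activity, read by MTT assay, with a stated time of 72 h; on this read-out higher numbers stand for weaker inhibition and lower numbers for stronger inhibition. Compound 1 `CCN1CCN(c2cc(C)c3cc(NC(=O)c4ccc5ccccc5n4)ccc3n2)CC1` gives 3760 nM, and compound 2 `CCN1CCN(c2cc(C)c3cc(NC(=O)c4cccnc4)ccc3n2)CC1` gives 10600 nM. Compound 2 therefore stands at the highest of the two numbers, the nearest being compound 1; the change was a 2.8-fold higher number from compound 1 to compound 2 (0.45 log units; beyond the scatter).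

Compound 3 `CCN1CCN(c2cc(C)c3cc(NC(=O)c4ccco4)ccc3n2)CC1` has not yet been measured. Its structure differs from compound 2 in one place: furan-2-yl in place of pyridin-3-yl on a carbonyl carbon. For the measured compounds named here, the only step that bears on this change is the one from compound 1 to compound 2, where an exchange of one aromatic ring for another on the same carbonyl carbon moved the number in this assay by a modest but measurable amount. That single step gives no direct guide to a furan-2-yl ring, so the expectation for compound 3 rests on the fact that compound 2 already sits at the weaker end of the pair; any move is expected to be small and uncertain in direction, with the estimated step being a 1.1-fold higher number from compound 2 to compound 3 (0.05 log units; within the scatter). Compound 3 is thus expected to give about 12000 nM, in a range from 4000 nM to 40000 nM.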

Compound 3, half-maximal inhibitory concentration: 37500 nM
The estimate for compound 3 lay 3.1-fold (0.49 log units) below the measured number; the range from low to high includes it.
By their numbers in this assay, from the lowest: compound 1; then compound 2; then compound 3.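

At this position on the carbonyl carbon, the ring carries more weight in this assay than the first pair alone could show: furan-2-yl in place of pyridin-3-yl gives a 3.5-fold higher number from compound 2 to compound 3 (0.55 log units; beyond the scatter), a larger move than the earlier exchange, even though both groups count the same hydrogen-bond donors and acceptors. Set against the quinolin-2-yl amide, the furan-2-yl group gives a 10-fold higher number from compound 1 to compound 3 (1.00 log units; beyond the scatter), and the three compounds now run from the lowest number to the highest in the order quinolin-2-yl, pyridin-3-yl, furan-2-yl, with each step beyond the usual scatter. No measurement shown here accounts for these differences.

The exchange of pyridin-3-yl for furan-2-yl alters ring size and the hetero atom together, so the compounds shown cannot say which of the two goes with the higher number. As far as these compounds go, a phenyl ring, a pyridin-2-yl ring or a thiophen-2-yl ring on the same carbonyl carbon would pull these apart, and whether the order seen here holds in any other cell line remains open as well.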